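A few compounds are considered here, and "the series" means these few. Any claim that something is new, unique, unknown or untested is made for them only; others in the source may bear on it.

In a functional assay on A549 cells (Homo sapiens) for inhibition, read by MTT assay, with a stated time of 48 h (a lower number here means a stronger inhibitor, a higher number a weaker inhibitor), compound 1 (`COc1ccc(-c2cc(NC(=O)Nc3ccccn3)cc(OC)c2OC)cn1`) gives 24700 nM while compound 3 (`O=C(Nc1ccncc1)Nc1cc(-c2cccnc2)ccc1OC(F)(F)F`) gives 39800 nM and the two lie within the scatter of each other. For compound 2 (`COc1cc(NC(=O)Nc2ccncc2)cc(-c2cccnc2)c1OC`) the entry reads "not determined" (no result reported) and no number exists. Compound 4 (`COc1ccc(-c2ccc(OC(F)(F)F)c(NC(=O)Nc3ccncc3)c2)cn1`) differs from compound 3 by one change (methoxy in place of hydrogen on an aromatic carbon) in which pyridin-3-yl becomes 6-methoxypyridin-3-yl, with methoxy in place of hydrogen on an aromatic carbon next to the ring nitrogen and para to a large group. Within the data shown here, no measured pair shows this change, so starting from compound 3 at 39800 nM the expected step in this assay is none beyond the scatter, with no direction favoured. The estimate for compound 4 is 32000 nM with an expected range from 13000 nM to 75000 nM for repeat measurements.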

Compound 4, half-maximal inhibitory concentration: > 300000 nM
Compound 4 was reported as a limit; the forecaster's own chance of this, stated with the estimate: 15%; middle value at least 9.3-fold (0.97 log units) from the limit.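

In this assay, among these compounds, the change from pyridin-3-yl to 6-methoxypyridin-3-yl gives the only step, an at least 7.5-fold higher number from compound 3 to compound 4 (0.87 log units; beyond the scatter). Among the compounds shown here, this is the first direct sign that the position on the aromatic carbon next to the ring nitrogen and para to a large group is sensitive to substitution, though only this pair shows it. The size of the step remains unknown, as the result for compound 4 is a limit, not a number: the limit of > 300000 nM in this assay, at which 1 of the 4 values shown sits.

Open, going by these compounds, is whether an amine, fluorine or a longer ethoxy chain at this position gives a similar step, and whether methoxy gives the same step on the core of compound 1.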